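Notes on the sulfoxide series: from compound 2 to compound 3

The compounds below may be only part of what the source reports. "The series", "measured", "known", "first", "only" and "open" are said of these compounds alone.

Two compounds of the series have numbers in a functional assay on U-937 cells (Homo sapiens) for antagonist activity, read by calcium flux; a higher number here means a weaker inhibitor, a lower number a stronger inhibitor. Compound 1 `COc1ccc(CCCCCCCCOc2ccc(CSc3cccc(C(=O)O)c3)nc2/C=C/C(=O)O)cc1` gives 390 nM. Within the data shown here, compound 2 `COc1ccc(CCCCCCCCOc2ccc(C[S+]([O-])c3cccc(N)c3)nc2/C=C/C(=O)O)cc1` gives 74 nM, the lowest of the two numbers; the single step between them, a 5.3-fold lower number from compound 1 to compound 2 (0.72 log units; beyond the scatter), exchanges the whole group on the saturated chain carbon bound to an aromatic carbon. Compound 3 `COc1ccc(CCCCCCCCOc2ccc(C[S+]([O-])c3cccc(N(C)C)c3)nc2/C=C/C(=O)O)cc1` is not yet measured. It differs from compound 2 by dimethylamino in place of amino on an aromatic carbon. Among the measured compounds shown here, no measured step touches this position: the step from compound 1 to compound 2 concerns a different part of the molecule, and nothing bears directly on this change. The expectation is therefore that compound 3 stays close to compound 2, with a step of a 1.1-fold higher number from compound 2 to compound 3 (0.06 log units; within the scatter) that is not expected to reach beyond the scatter. Compound 3 is estimated at 85 nM, within 30 nM to 250 nM.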

Compound 3, half-maximal inhibitory concentration: 820 nM
Compound 3: middle estimate off by 9.6-fold (0.98 log units), on the low side; measured number outside the range, above it.
By their numbers in this assay, from the lowest: compound 2; then compound 1; then compound 3.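

Among these compounds, at this position the aromatic amino group is not a silent place in the molecule: in this assay, dimethylamino in place of amino gives an 11-fold higher number from compound 2 to compound 3 (1.04 log units; beyond the scatter), the largest step so far. The whole-group exchange that lowered the number from compound 1 to compound 2 therefore depends on what sits on that aromatic carbon, as the same exchange with dimethylamino gives a 2.1-fold higher number from compound 1 to compound 3 (0.32 log units; beyond the scatter) and ends on the opposite side of compound 1. The data available give no explanation for the size of this step.

A methylamino or acetamido group at this position would show whether the change follows from one added carbon or needs both. A sulfide bearing the same amino group would separate the sulfur oxidation state from the exchange of the aromatic substituent.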